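Sec-butyl to pentan-3-yl on the shared core

The source may report more compounds than this note shows. Statements on the series, on what has been measured and on what is new or still open speak of the compounds shown alone.

In a functional assay (Nicotiana tabacum) (a lower number here means a stronger inhibitor, a higher number a weaker inhibitor), three amines on the shared core have numbers. Compound 1 `CCCCCCNc1nc(SC)nc2ncccc12`, the hexyl member, gives 3330 nM. Compound 2 `CSc1nc(NC2CCCC2)c2cccnc2n1`, the cyclopentyl member, gives 490 nM. Compound 3 `CCC(C)Nc1nc(SC)nc2ncccc12`, the sec-butyl member, gives 860 nM. That value stands clear of the hexyl member, with a 3.9-fold lower number from compound 1 to compound 3 (0.59 log units; beyond the scatter), but is not separated from the cyclopentyl member, with a 1.8-fold higher number from compound 2 to compound 3 (0.24 log units; within the scatter).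

The next member is compound 4 `CCC(CC)Nc1nc(SC)nc2ncccc12`. The change is methyl in place of hydrogen on a saturated chain carbon, two bonds along the chain from a nitrogen on an aromatic ring, which turns sec-butyl into pentan-3-yl.

Among the measured compounds shown here, no measured step makes this exact change, so the evidence is indirect. Leaving hexyl gave modest steps, a 6.8-fold lower number from compound 1 to compound 2 (0.83 log units; beyond the scatter) and the one to the sec-butyl member already noted. Those steps show that the hexyl member differs from the other two. The exchange between sec-butyl and cyclopentyl stayed within the scatter, and this is the closer guide for a change of this size. A small step towards the cyclopentyl value is therefore expected, and no step beyond the scatter is anticipated.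

The estimate means a 1.4-fold lower number from compound 3 to compound 4 (0.16 log units; within the scatter), an expected shift that stays within the scatter. Compound 4 is expected at 600 nM. The estimated range for compound 4 runs from 280 nM to 1300 nM.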

Compound 4, half-maximal inhibitory concentration: 2720 nM
Beside the measured number, compound 4's estimate is 4.5-fold (0.66 log units) below it, outside the stated range (above it).
By their numbers in this assay, from the lowest: compounds 2 and 3 (each within the scatter of the next); then compounds 4 and 1 (each within the scatter of the next).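

In this assay, the methyl on a saturated chain carbon, two bonds along the chain from a nitrogen on an aromatic ring, is not a neutral addition: the result is a 3.2-fold higher number from compound 3 to compound 4 (0.50 log units; beyond the scatter) and shows that one added carbon at this place can move the number beyond the scatter, which the exchange between sec-butyl and cyclopentyl did not show. The pentan-3-yl group also parts from the cyclopentyl group, with a 5.6-fold higher number from compound 2 to compound 4 (0.74 log units; beyond the scatter), while it is not separated from the hexyl group, with a 1.2-fold lower number from compound 1 to compound 4 (0.09 log units; within the scatter), so the four amines now fall into two sets, sec-butyl with cyclopentyl and pentan-3-yl with hexyl. Nothing in the available data offers an explanation for this split.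

The compounds shown leave open whether the smaller isopropyl group would stay with the sec-butyl and cyclopentyl set, and whether the larger heptan-4-yl group would keep to the level of the pentan-3-yl group or move further. They also leave open whether a cyclobutyl or cyclohexyl ring on the nitrogen would stay with the cyclopentyl group or part from it as the pentan-3-yl group does.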